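This account rests on a few compounds, and the source may have more. Where it says the series, first, only, none or still open, it means among the compounds named here.

Measured compounds and values in a functional assay on HCT-116 cells (Homo sapiens) for inhibition, read by CCK-8 assay, with a stated time of 48 h; a higher number here means a weaker inhibitor, a lower number a stronger inhibitor:

Compound 1, `COc1cc(-c2cc3nccc(-c4c[nH]c5ccccc45)n3n2)cc(OC)c1OC`, gives > 10000 nM; this value is a limit of the assay and not a number.
Compound 2, `COc1cc(-c2ccnc3cc(-c4ccc(C(F)(F)F)cc4)nn23)cc(OC)c1OC`, gives 1860 nM.
Compound 3, `Cc1ccc(-c2cc3nccc(-c4ccc(F)cc4)n3n2)cc1`, gives > 10000 nM; this value is also a limit of the assay and not a number.

Among the compounds with values here, compound 2 therefore stands as the only measured number in this assay; the other two entries are limits, as noted in the limit of > 10000 nM in this assay, at which 2 of the 3 values shown sit. Within the data shown here, no pair of measured compounds differs in a single place, so there is no measured step on which to anchor the size of a change, and any expectation for the next compound rests on the structural change alone.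

Compound 4, `COc1cc(-c2ccnc3cc(-c4ccc(C(C)(C)C)cc4)nn23)cc(OC)c1OC`, differs from compound 2 in one place: tert-butyl in place of trifluoromethyl on an aromatic carbon.

Among the measured compounds shown here, with no measured step to compare against, the expected step in this assay is a small one, either toward weaker inhibition or none beyond the usual scatter; the step from compound 2 to compound 4 is estimated at a 1.5-fold higher number from compound 2 to compound 4 (0.18 log units; within the scatter). Compound 4 is accordingly expected to give about 2800 nM in this assay, with a plausible range from 900 nM to 9000 nM.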

Compound 4, half-maximal inhibitory concentration: > 10000 nM
Compound 4: only a limit was reported; the forecaster's own chance of this, stated with the estimate: 20%; at least 3.5-fold (0.55 log units) between middle value and limit.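

In this assay, within the data shown here, 4-(tert-butyl)phenyl in place of 4-(trifluoromethyl)phenyl gives an at least 5.3-fold higher number from compound 2 to compound 4 (0.73 log units; beyond the scatter), the first single-place step, and it shows that this position is not indifferent to the group it carries. Compound 4 gives > 10000 nM, which is a limit of the assay and not a number. The step is therefore a minimum, and compound 2 remains the only compound with a measured number here: the limit of > 10000 nM in this assay, at which 3 of the 4 values shown sit.

Still open, on these data alone, is how a nitrile, an amine or a carboxylic acid in place of trifluoromethyl would read in this assay, and whether any group at this position gives a lower number than compound 2 at 1860 nM. As far as these compounds go, whether the same change would have a similar effect on the core of compound 3 also remains open.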